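Hydrazone aryl variations on a shared core: cytotoxicity notes

The source may hold more compounds than are shown below. What is called first, only, known or untested is meant among the compounds shown, and "the series" means these compounds.

Measured compounds:
- compound 1 `CN(C)CCn1cnnc1-c1cc(Oc2ccc(NC(=O)N/N=C/c3ccccc3)cc2F)ccn1` gives 1860 nM in a functional assay on A549 cells (Homo sapiens) for cytotoxicity, read by MTT assay, with a stated time of 72 h; on this read-out lower numbers stand for stronger inhibition and higher numbers for weaker inhibition
- compound 2 `CN(C)CCn1cnnc1-c1cc(Oc2ccc(NC(=O)N/N=C/c3ccc(F)cc3)cc2F)ccn1` gives 1790 nM in this assay
- compound 3 `CN(C)CCn1cnnc1-c1cc(Oc2ccc(NC(=O)N/N=C/c3ccc(O)cc3)cc2F)ccn1` gives 3560 nM in this assay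

The three measured compounds share one core and differ only in the aryl end of the hydrazone. Compound 1 to compound 2 is fluoro in place of hydrogen on an aromatic carbon; its step in this assay is a 1.0-fold lower number from compound 1 to compound 2 (0.02 log units; within the scatter). Compound 1 to compound 3 is hydroxy in place of hydrogen on an aromatic carbon, with a 1.9-fold higher number from compound 1 to compound 3 (0.28 log units; within the scatter). Compound 2 to compound 3 shows a 2.0-fold higher number from compound 2 to compound 3 (0.30 log units; within the scatter). None of these steps leaves the scatter.

Compound 4 `CN(C)CCn1cnnc1-c1cc(Oc2ccc(NC(=O)N/N=C/c3ccc(O)c(F)c3)cc2F)ccn1` is not yet measured. It differs from compound 3 by fluoro in place of hydrogen on an aromatic carbon. This is the same kind of change as compound 1 to compound 2, but the place differs: there the fluoro enters para to a large group, here it enters ortho to a hydroxy group and meta to a large group. Because the earlier step of a 1.0-fold lower number from compound 1 to compound 2 (0.02 log units; within the scatter) stayed within the scatter, a step of similar size is expected here, a 1.1-fold lower number from compound 3 to compound 4 (0.05 log units; within the scatter). Compound 4 is therefore estimated at 3200 nM in this assay.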

Compound 4, half-maximal inhibitory concentration: 13400 nM
Estimate against measurement, compound 4: 4.2-fold (0.62 log units) below; measured number above the stated range.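

In this assay, fluoro in place of hydrogen on an aromatic carbon does not carry over unchanged from the core of compound 1 to the core of compound 3, and the two steps differ: the same change on two cores in this assay, a 1.0-fold lower number (0.02 log units; within the scatter) from compound 1 to compound 2 and a 3.8-fold higher number (0.58 log units; beyond the scatter) from compound 3 to compound 4, 3.9-fold (0.59 log units) apart, beyond the scatter of two such steps.

Within this set, compound 4 stands apart from each of the other three, with a 3.8-fold higher number from compound 3 to compound 4 (0.58 log units; beyond the scatter) and a 7.5-fold higher number from compound 2 to compound 4 (0.87 log units; beyond the scatter) and a 7.2-fold higher number from compound 1 to compound 4 (0.86 log units; beyond the scatter) on the same read-out. For the compounds shown here, the pairs do not show what sets the gap between the two fluoro steps, whether the hydroxy group or the place of the fluoro, ortho to a hydroxy group and meta to a large group, and each core supplies only one such step.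

Still open, on these data alone, is what the 3-fluorophenyl end, with the fluoro at that place and no hydroxy group, would give on the shared core. Also open, as far as these compounds go, is whether chloro in place of that fluoro, or methoxy in place of that hydroxy, would give a step of similar size in this assay.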